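A Methoxy Group Added to the Chain of Compound 1

The source may report more compounds than this note shows. Statements on the series, on what has been measured and on what is new or still open speak of the compounds shown alone.

Measured so far:
- compound 1, `CO/N=C(\CCN1CCN(c2ccccn2)CC1)c1ccc(Cl)cc1`: 37.6 nM
- compound 2, `CO/N=C(\CCN1CCN(c2ccccn2)CC1)c1ccc(Cl)c(Cl)c1`: 542 nM
- compound 3, `CO/N=C(\CCN1CCN(c2ccccn2)CC1C)c1ccc(Cl)cc1`: 333 nM

In a functional assay on HEK293 cells with D(4) dopamine receptor (Homo sapiens) as the target, read by FLIPR (a lower number here means that less compound is needed, a higher number that more compound is needed for the effect), compound 1 gives 37.6 nM, the lowest of the three numbers; compound 3 and compound 2 both need more compound. Compound 4, `CO/N=C(/c1ccc(Cl)cc1)C(CN1CCN(c2ccccn2)CC1)OC`, keeps the core of compound 1 and differs in one place: methoxy in place of hydrogen on a saturated chain carbon bound to a carbon with a double bond to nitrogen and a saturated chain carbon.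

Neither measured step touches this exact place, so none bears on it directly. What the two steps do show is how compound 1 responds to additions elsewhere: a chloro added to the aromatic ring gave a 14-fold higher number from compound 1 to compound 2 (1.16 log units; beyond the scatter), and a methyl on the saturated ring gave an 8.9-fold higher number from compound 1 to compound 3 (0.95 log units; beyond the scatter). Both additions, at different places, raised the number beyond the scatter. On that basis an increase in this assay is expected for compound 4 as well, though its size is uncertain because the place is new.

Compound 4 is therefore estimated at 300 nM, within a range of 60 nM to 1500 nM, which would mean an expected step of an 8.0-fold higher number from compound 1 to compound 4 (0.90 log units; beyond the scatter).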

Compound 4, half-maximal effective concentration: 285 nM
Beside the measured number, compound 4's estimate is 1.1-fold (0.02 log units) above it, within the range that was stated.
By their numbers in this assay, from the lowest: compound 1; then compounds 4, 3 and 2 (each within the scatter of the next).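

In this assay, among the compounds shown here, methoxy in place of hydrogen on this saturated chain carbon gives a 7.6-fold higher number from compound 1 to compound 4 (0.88 log units; beyond the scatter) and so shows that the chain of compound 1 also responds to substitution, which the earlier steps, both made elsewhere on the molecule, could not show. Compound 2, compound 3 and compound 4 now carry additions at three different places, and each has a higher number than compound 1 by more than the scatter. Nothing available here gives a reason for the rise at this carbon. From the compounds shown here alone, whether it belongs to methoxy itself or would follow any replacement of hydrogen at this carbon remains open. A hydroxyl, a fluorine, an amine or a longer ether such as ethoxy at the same place could separate these possibilities and show whether any group here can lower the number.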